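The compounds below may be only part of what the source reports. "The series", "measured", "known", "first", "only" and "open" are said of these compounds alone.

Series notes. The parent is compound 1 `COc1ccc(Nc2ncc(C(F)(F)F)c(N3Cc4cccc(N(C)S(C)(=O)=O)c4C3)n2)cc1C(F)(F)F`. In a functional assay on A549 cells (Homo sapiens) for antiproliferative activity, read by spectrophotometry, with a stated time of 2 days (a lower number here means a stronger inhibitor of growth, a higher number a weaker inhibitor of growth), compound 1 gives only a limit, > 30000 nM. Compound 2 `Cc1ccc(Nc2ncc(C(F)(F)F)c(N3Cc4cccc(N(C)S(C)(=O)=O)c4C3)n2)c(Cl)c1` carries 2-chloro-4-methylphenyl in place of 4-methoxy-3-(trifluoromethyl)phenyl on a nitrogen on an aromatic ring; in this assay compound 2 likewise gives a limit, > 30000 nM. Compound 3 `Cc1cc(F)ccc1Nc1ncc(C(F)(F)F)c(N2Cc3cccc(N(C)S(C)(=O)=O)c3C2)n1` has 4-fluoro-2-methylphenyl on that nitrogen; in this assay compound 3 also gives a limit, > 30000 nM. The three steps among them, a step that the two limits leave unreadable from compound 1 to compound 2, a step that the two limits leave unreadable from compound 1 to compound 3 and a step that the two limits leave unreadable from compound 2 to compound 3, therefore carry no readable size, the common ground being (the limit of > 30000 nM in this assay, at which 3 of the 3 values shown sit).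

Compound 4 `CN(c1cccc2c1CN(c1nc(Nc3cccc(C(F)(F)F)c3)ncc1C(F)(F)F)C2)S(C)(=O)=O` differs from compound 1 by hydrogen in place of methoxy on an aromatic carbon. Going by the values given here, no measured step bears directly on this change; every step recorded exchanges the whole aryl group on the nitrogen, and every one of them comes to rest at the same limit. On that footing the change is expected to leave compound 4 where compound 1 stands, with the step of a number no higher from compound 1 to compound 4 (the limit leaves the size open) expected to be unreadable in the same way. For compound 4 the estimate in this assay is 30000 nM, within 5000 nM to 100000 nM, with a strong chance that only a limit is again reported.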

Compound 4, concentration for 50% growth inhibition: > 30000 nM
Compound 4: only a limit was reported; the forecaster's own chance of this, stated with the estimate: 85%; the middle value lies on the limit itself.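

Compound 4 gives only a limit in this assay, as do compound 1, compound 2 and compound 3, so none of the new steps to compound 4 can be read: the limit of > 30000 nM in this assay, at which 4 of the 4 values shown sit.

The compounds shown leave open whether any aryl group on that nitrogen, or hydrogen in place of methoxy, changes the read-out in this assay at all.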